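Fluoro in place of cyano: expected step in the series

The compounds below may be only part of what the source reports. "The series", "measured", "known", "first", "only" and "open" are said of these compounds alone.

In a functional assay on the whole organism (stomach) for inhibition, with Rattus norvegicus as the target (on this read-out lower numbers stand for an effect already at smaller amounts and higher numbers for an effect only at larger amounts of compound), compound 1 (`CC1(C)OC(/C=C/c2ccc(C#N)cc2)=CC1=O`) gives 50 mg/kg and compound 2 (`CC1(C)OC(/C=C/c2ccccn2)=CC1=O`) gives 40 mg/kg. Within the data shown here, these two values lie within the usual scatter of each other, so compound 1 stands level with the only other measured compound. The next structure, compound 3 (`CC1(C)OC(/C=C/c2ccc(F)cc2)=CC1=O`), keeps the core of compound 1 and carries fluoro in place of cyano on an aromatic carbon, para to a large group: fluoro in place of cyano on an aromatic carbon. Among the measured compounds shown here, no two measured compounds differ in one place only, so the data do not show how this assay responds to a change of this kind. Starting from compound 1 at 50 mg/kg, no step beyond the scatter is expected, and no firm direction. The estimated change is small: a 1.3-fold lower number from compound 1 to compound 3 (0.10 log units; within the scatter). Compound 3 is expected at 40 mg/kg, with an estimated range of 15 mg/kg to 100 mg/kg.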

Compound 3, dose for half-maximal effect: 50 mg/kg
The estimate for compound 3 lay 1.3-fold (0.10 log units) below the measured number, within the range that was stated.
By their numbers in this assay, from the lowest: compounds 2, 1 and 3 (each within the scatter of the next).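

In this assay, fluoro in place of cyano on an aromatic carbon, para to a large group, gives no change at the digits printed from compound 1 to compound 3 (within the scatter). Among these compounds, this is the first single-place step, and it shows that this position tolerates the exchange without a step beyond the scatter. The triple bond and the hydrogen-bond acceptor that leave with cyano are thus not needed to hold the number at this level, at least in this one pair, and no measurement available here explains the result.

On these data alone, whether an amine or a carboxylic acid at this position would give a step beyond the scatter remains open. As far as these compounds go, with a single one-place pair, it also remains open whether any change on the shared core moves the number in either direction.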